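Swapping a Benzylamine Linker for an Aryl Sulfide

A few compounds are considered here, and "the series" means these few. Any claim that something is new, unique, unknown or untested is made for them only; others in the source may bear on it.

Measured compounds:
compound 1 `COc1ccc(CNc2nc3cc(N)cc(N)c3nc2-c2ccccc2)cc1OC`, 2690 nM
compound 2 `Nc1cc(N)c2nc(-c3ccccc3)c(NCc3ccc(F)cc3)nc2c1`, 1700 nM
compound 3 `COc1ccc(CNc2nc3cc(N)cc(N)c3nc2-c2ccccc2)cc1`, 8130 nM

These three compounds share one core and differ only in the group attached through a saturated chain carbon to a ring nitrogen. In a functional assay on OVCAR-4 cells (Homo sapiens) for inhibition, read by sulforhodamine B assay, with a stated time of 48 h (a lower number here means a stronger inhibitor of growth, a higher number a weaker inhibitor of growth), compound 2 gives the lowest number of the three. Its nearest neighbour is compound 1, a step of a 1.6-fold lower number from compound 1 to compound 2 (0.20 log units; within the scatter), which is within the scatter, so the two cannot be ordered. Compound 3 stands furthest away: a 4.8-fold higher number from compound 2 to compound 3 (0.68 log units; beyond the scatter), and likewise a 3.0-fold higher number from compound 1 to compound 3 (0.48 log units; beyond the scatter).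

Compound 4 `Nc1cc(N)c2nc(-c3ccccc3)c(Sc3ccc(F)cc3)nc2c1` changes a different part of the molecule: (4-fluorophenyl)sulfanyl in place of (4-fluorobenzyl)amino on an aromatic carbon. Within the data shown here, none of the measured steps alters this linker; all three concern only the substituents on the pendant aromatic ring, so no measured step bears directly on this change. The 4-fluorophenyl ring itself is kept. Among the measured compounds shown here, with no comparable step available, the expectation for compound 4 is a number near that of compound 2, with wide uncertainty, and the expected step is a 1.5-fold higher number from compound 2 to compound 4 (0.17 log units; within the scatter). In this assay compound 4 is therefore estimated at 2500 nM, within a range from 800 nM to 8000 nM.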

Compound 4, concentration for 50% growth inhibition: 22900 nM
For compound 4 the middle estimate is 9.2-fold (0.96 log units) below the measured one; the measured number lies above the stated range.
By their numbers in this assay, from the lowest: compounds 2 and 1 (each within the scatter of the next); then compound 3; then compound 4.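

In this assay, among these compounds, the linker turns out to matter more than anything the earlier compounds varied: the change gives a 13-fold higher number from compound 2 to compound 4 (1.13 log units; beyond the scatter), a step larger than any among compounds 1, 2 and 3, even though the 4-fluorophenyl ring is kept. This single swap alters several things at once, since the (4-fluorobenzyl)amino group, with 1 hydrogen-bond donor, gives way to the (4-fluorophenyl)sulfanyl group, with 0 hydrogen-bond donors, and both the nitrogen and the saturated chain carbon leave as sulfur enters. Nothing measured here shows which of these differences accounts for the step.

The compounds shown leave open whether the nitrogen or the chain carbon is what counts: a (4-fluorophenyl)amino group would keep the nitrogen without the chain carbon, while a (4-fluorobenzyl)sulfanyl group would keep the chain carbon with sulfur in place of the nitrogen. Also open, from the compounds shown here alone, is whether the steps seen between ring substituents on the amino linker carry over to the sulfur linker, as a (4-methoxyphenyl)sulfanyl group could show.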